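The source may report more compounds than this note shows. Statements on the series, on what has been measured and on what is new or still open speak of the compounds shown alone.

Compound 1 `C[C@H](c1ccc(-c2cc(Cl)ccc2-c2nc(=O)o[nH]2)cc1)N(CC1CC1)c1nc2c(C(=O)O)cccc2o1` is the starting point here. In an ADME assay on the whole organism (Macaca fascicularis) for metabolic stability, read by LC-MS, using cassette dosing, at a dose of 1 mg/kg by the oral route (a higher number here means that the compound lasts longer, a lower number that the compound disappears faster), compound 1 gives 0.8 h, which is the lowest of the three numbers available. Compound 2 `CCCCN(c1nc2c(C(=O)O)cccc2o1)[C@H](C)c1ccc(-c2cc(Cl)ccc2-c2nc(=O)o[nH]2)cc1` differs from it in one place, carrying a propyl chain in place of the cyclopropyl on the saturated carbon bound to the ring nitrogen, and in this assay compound 2 gives 2 h; the step from compound 1 to compound 2 is a 2.5-fold higher number from compound 1 to compound 2 (0.40 log units; beyond the scatter). Compound 3 `CCCCN(c1nc2c(C(=O)NS(C)(=O)=O)cccc2o1)[C@H](C)c1ccc(-c2ccccc2-c2nnn[nH]2)cc1`, which differs from both in several places at once, gives 2.7 h in this assay, so the two values of compound 1 and compound 3 differ more widely than those of compound 1 and compound 2.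

The next compound, compound 4 `C[C@H](c1ccc(-c2cc(F)ccc2-c2nc(=O)o[nH]2)cc1)N(CC1CC1)c1nc2c(C(=O)O)cccc2o1`, changes a different part of compound 1: fluoro in place of chloro on an aromatic carbon. Among the compounds with values here, none of the measured steps touches this halogen position; the only single-point step, from compound 1 to compound 2, concerns the chain on the nitrogen and so gives no guide to a swap of chloro for fluoro. With nothing in the data pointing either way, the step from compound 1 to compound 4 in this assay is expected to be no change at the digits printed from compound 1 to compound 4 (within the scatter), that is, no change beyond the usual scatter. Compound 4 is therefore estimated at 0.8 h, within a range from 0.4 h to 1.7 h.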

Compound 4, half-life: 4.1 h
For compound 4 the middle estimate is 5.1-fold (0.71 log units) below the measured one; measured number above the stated range.
By their numbers in this assay, from the lowest: compound 1; then compounds 2, 3 and 4 (each within the scatter of the next, the first and the last beyond it).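

Swapping chloro for fluoro on this aromatic carbon exchanges one heavy atom for another, with no ring, no hydrogen-bond donor or acceptor and no net charge on either side, and yet in this assay it gives a 5.1-fold higher number from compound 1 to compound 4 (0.71 log units; beyond the scatter). Within the data shown here, until now the only single change on record was at the chain on the nitrogen, which gave a 2.5-fold higher number from compound 1 to compound 2 (0.40 log units; beyond the scatter) in the same assay, so the halogen position is now a second place on compound 1 where one change moves the half-life beyond the scatter. The compounds shown offer no independent measurement that accounts for this difference between the two halogens.

Still open, on these data alone, is whether the half-life at this position follows the identity of the group more widely, which a bromo group, a methyl group or a plain hydrogen on the same carbon would help to show, since compound 3 differs from compound 1 in several places at once and cannot answer this. Also open, as far as these compounds go, is whether fluoro would have a similar effect on a compound carrying the propyl chain of compound 2, where the two changes would be combined.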